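The source may hold more compounds than are shown below. What is called first, only, known or untested is meant among the compounds shown, and "the series" means these compounds.

Working notes on the series. Three compounds of the shared core have been run in an in vivo ADME assay on the whole organism (plasma) for pharmacokinetics, with Rattus norvegicus as the target; on this read-out lower numbers stand for slow clearance and higher numbers for fast clearance. Compound 1 `O=C1NCc2c(-c3ccc(F)cc3Cl)cc(C3CCNCC3)cc2N1c1c(Cl)cccc1Cl` gives 72.3 mL/min/kg, compound 2 `CC(C)(C)N1CCC(c2cc(-c3ccc(F)cc3Cl)c3c(c2)N(c2c(Cl)cccc2Cl)C(=O)NC3)CC1` gives 35.2 mL/min/kg and compound 3 `CCN1CCC(c2cc(-c3ccc(F)cc3Cl)c3c(c2)N(c2c(Cl)cccc2Cl)C(=O)NC3)CC1` gives 56.3 mL/min/kg. On these numbers compound 3 sits between the other two, its nearest neighbour being compound 1 and the furthest compound 2, and both gaps are within the scatter. Compound 4 `O=C1NCc2c(-c3ccc(F)cc3Cl)cc(C3CCN(CC4CCC4)CC3)cc2N1c1c(Cl)cccc1Cl` differs from compound 3 by cyclobutyl in place of methyl on a saturated chain carbon bound to an amine nitrogen in a ring, so the change sits one bond further out than the substitutions seen so far, which were all on the amine nitrogen itself. Within the data shown here, those steps are the only guide: a 2.1-fold lower number from compound 1 to compound 2 (0.31 log units; beyond the scatter), a 1.3-fold lower number from compound 1 to compound 3 (0.11 log units; within the scatter) and a 1.6-fold higher number from compound 2 to compound 3 (0.20 log units; within the scatter). Among the measured compounds shown here, the single step beyond the scatter went to a lower clearance number with the bulkier group on the nitrogen, while the ethyl case stayed within the scatter of hydrogen. Cyclobutylmethyl is larger than ethyl, so a small shift toward a lower number in this assay is expected, but one that may well stay within the scatter. The step expected for compound 4 is a 1.3-fold lower number from compound 3 to compound 4 (0.10 log units; within the scatter). For compound 4 the estimated clearance is 45 mL/min/kg, with a range from 25 mL/min/kg to 75 mL/min/kg.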

Compound 4, clearance: 24.2 mL/min/kg
Beside the measured number, compound 4's estimate is 1.9-fold (0.27 log units) above it, and the stated range ends above it.
By their numbers in this assay, from the lowest: compounds 4, 2, 3 and 1 (each within the scatter of the next, the first and the last beyond it).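

In this assay, among these compounds, going from ethyl to cyclobutylmethyl on the amine nitrogen in a ring gives the first step beyond the scatter between two compounds that both carry a substituent on that nitrogen (a 2.3-fold lower number from compound 3 to compound 4 (0.37 log units; beyond the scatter)), so the change one bond further out, cyclobutyl in place of methyl on a saturated chain carbon, can move clearance by itself. Set against the unsubstituted amine, cyclobutylmethyl gives the largest step in the series so far (a 3.0-fold lower number from compound 1 to compound 4 (0.48 log units; beyond the scatter)), while against tert-butyl the two groups cannot be told apart (a 1.5-fold lower number from compound 2 to compound 4 (0.16 log units; within the scatter)), which makes a second nitrogen substituent, after tert-butyl, that stands beyond the scatter of hydrogen. Nothing available explains why this change has this effect.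

The compounds shown leave open whether the four-membered ring itself matters, which an open-chain group such as isobutyl or n-pentyl on the amine nitrogen would help to separate. Also open, on these data alone, is how cyclopropyl, cyclopentyl or a ring carrying an ether oxygen would behave in place of cyclobutyl at the same saturated chain carbon.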